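This account rests on a few compounds, and the source may have more. Where it says the series, first, only, none or still open, it means among the compounds named here.

In a functional assay on HL-60 cells (Homo sapiens) for inhibition, read by MTT assay, with a stated time of 48 h, tested at 10 uM (on this read-out higher numbers stand for more inhibition of growth at the one concentration tested and lower numbers for less inhibition of growth), compound 2 `Cc1cc(=O)c2c(O)c(CN3CCC(N4CCCCC4)CC3)c(O)c([C@H]3CCN(C)C[C@H]3O)c2o1` gives 34%, the higher of the two numbers recorded so far. Compound 1 `COc1ccc(COc2cc(O)c3c(=O)cc(C)oc3c2[C@H]2CCN(C)C[C@H]2O)cc1` gives 23% in this assay, a gap from compound 2 that lies beyond the usual scatter. Compound 3 `Cc1cc(=O)c2c(O)c(CN3CCCCC3)c(O)c([C@H]3CCN(C)C[C@H]3O)c2o1` has not yet been measured; it differs from compound 2 by hydrogen in place of piperidin-1-yl on a saturated ring carbon. Going by the values given here, no step between measured compounds is available to set a scale for this change, so only a modest shift downward, or none beyond the scatter, is expected: a number 6 percentage points lower from compound 2 to compound 3 (within the scatter). For compound 3 the expected value is 28%, with a range from 14% to 42%.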

Compound 3, percent growth inhibition at one concentration: 32%
Compound 3: middle estimate off by 4 percentage points, on the low side, within the range that was stated.
By their numbers in this assay, from the lowest: compounds 1, 3 and 2 (each within the scatter of the next, the first and the last beyond it).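

In this assay, hydrogen in place of piperidin-1-yl on a saturated ring carbon gives a number 2 percentage points lower from compound 2 to compound 3 (within the scatter). This first step at this place shows that the read-out does not depend on the piperidin-1-yl group here, since a whole six-membered ring can go without a change beyond the scatter. Nothing available gives a reason for this result. From the compounds shown here alone, what a primary amine, a carboxylic acid or a longer alkyl chain on that same ring carbon would do remains open. So does whether this step would look the same at other concentrations.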